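Series notes: aryl substituent exchange toward compound 3

A few compounds are considered here, and "the series" means these few. Any claim that something is new, unique, unknown or untested is made for them only; others in the source may bear on it.

Measured so far:
compound 1 `Cc1ccc(S(=O)(=O)/C=C/S(=O)(=O)CC2=NCCS2)cc1` — 21.7%
compound 2 `O=S(=O)(/C=C/S(=O)(=O)c1ccc(Cl)cc1)CC1=NCCO1` — 85.5%

In a functional assay for inhibition, tested at 100 uM (a higher number here means more inhibition at the concentration tested (going by the name of the read-out), a lower number less inhibition), compound 2 gives 85.5%, the higher of the two numbers; compound 1 gives 21.7%, a gap beyond the scatter. Compound 3 `Cc1ccc(S(=O)(=O)/C=C/S(=O)(=O)CC2=NCCO2)cc1` shares the core of compound 2 and differs from it by methyl in place of chloro on an aromatic carbon. Among the measured compounds shown here, compound 1 also carries the methyl-bearing aryl ring but differs from compound 3 elsewhere as well, so no single measured step isolates this change. Because compound 1 gives 21.7% with that aryl group, a decrease is expected; the expected step of a number 30.5 percentage points lower from compound 2 to compound 3 (beyond the scatter) is moderate and beyond the scatter. Compound 3 is estimated at 55%, within 20% to 85%.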

Compound 3, a percentage reported as inhibition, at one concentration (the size of the read-out at that concentration, not a potency): 74.2%
Compound 3: middle estimate off by 19.2 percentage points, on the low side, within the range that was stated.
By their numbers in this assay, from the lowest: compound 1; then compound 3; then compound 2.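

In this assay the exchange of 4-chlorophenyl for 4-methylphenyl on the shared core gives a number 11.3 percentage points lower from compound 2 to compound 3 (beyond the scatter) and leaves a high number, so the methyl-bearing aryl group is compatible with substantial inhibition. With that aryl group held constant, the exchange of the sulfur-containing ring for the oxygen-containing ring gives the much larger a number 52.5 percentage points higher from compound 1 to compound 3 (beyond the scatter) as a result. No data bearing on the cause of either step are available. Still open, from the compounds shown here alone, is how methoxy, an amine or a carboxylic acid would read on this aromatic carbon. Also open, going by these compounds, is whether the ring exchange gives a similar step with 4-chlorophenyl in place.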